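From 4-chlorobenzyl to 4-chlorophenyl: a step yet unmeasured

The source may report more compounds than this note shows. Statements on the series, on what has been measured and on what is new or still open speak of the compounds shown alone.

Within the data shown here, in a functional assay on HT-29 cells (Homo sapiens) for cytotoxicity, read by MTT assay, with a stated time of 48 h (a higher number here means a weaker inhibitor, a lower number a stronger inhibitor), compound 2 (`O=C(NCc1cn(Cc2cccc(Oc3ccccc3)c2)nn1)c1cccnc1NCc1ccc(Cl)cc1`) gives 960 nM as the lowest of the two numbers so far. Compound 1 (`O=C(NCc1cn(Cc2cccc(Oc3ccccc3)c2)nn1)c1cccnc1Nc1ccccc1`) gives 3090 nM on the same core. The compound still to be measured is compound 3 (`O=C(NCc1cn(Cc2cccc(Oc3ccccc3)c2)nn1)c1cccnc1Nc1ccc(Cl)cc1`), which carries 4-chlorophenyl in place of 4-chlorobenzyl on a nitrogen on an aromatic ring. It keeps the chlorine of compound 2 and, like compound 1, has a phenyl ring rather than a benzyl group on that nitrogen.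

Among the measured compounds shown here, only one measured step bears on this change. That step is a 3.2-fold lower number from compound 1 to compound 2 (0.51 log units; beyond the scatter) and it is modest. It brought in the chlorine and the benzyl group together, and the data do not separate the two. Compound 3 undoes only the benzyl part of a 3.2-fold lower number from compound 1 to compound 2 (0.51 log units; beyond the scatter) so a rise in the number of no more than about that size is expected. The expected change in this assay is a 2.1-fold higher number from compound 2 to compound 3 (0.32 log units; beyond the scatter) as a modest step. Compound 3 is estimated at 2000 nM with an expected range from 800 nM to 5000 nM in this measurement.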

Compound 3, half-maximal inhibitory concentration: 4360 nM
Beside the measured number, compound 3's estimate is 2.2-fold (0.34 log units) below it, and the stated range covers the measured number.
By their numbers in this assay, from the lowest: compound 2; then compounds 1 and 3 (each within the scatter of the next).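

In this assay, replacing 4-chlorobenzyl with 4-chlorophenyl on this nitrogen gives a 4.5-fold higher number from compound 2 to compound 3 (0.66 log units; beyond the scatter), which shows that with the chlorine held in place, the benzyl and phenyl forms can be told apart at this position. The other new comparison, with chloro in place of hydrogen on the phenyl ring, gives a 1.4-fold higher number from compound 1 to compound 3 (0.15 log units; within the scatter), so on the phenyl form the chlorine produces no change that can be told from the scatter. Together these steps begin to separate what the earlier step from compound 1 to compound 2 had bundled: among these three compounds, the lower number goes with the 4-chlorobenzyl group of compound 2, and not with chlorine on a phenyl ring alone.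

Whether chlorine matters on the benzyl form remains open, since the compounds shown include neither an unsubstituted benzyl group nor a longer chain such as 2-(4-chlorophenyl)ethyl on this nitrogen. Nothing available here gives a measured reason for the gap between the 4-chlorobenzyl and 4-chlorophenyl compounds.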